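Cyclohexyl to 2-bromophenyl on the amide nitrogen

This account rests on a few compounds, and the source may have more. Where it says the series, first, only, none or still open, it means among the compounds named here.

Measured so far:
compound 1, `CCOC(=O)C1=Cc2ccccc2OC1(OCc1cn(CC(=O)NC2CCCCC2)nn1)C(F)(F)F`, 9900 nM
compound 2, `CCOC(=O)C1=Cc2ccccc2OC1(OCc1cc(-c2ccc3ccccc3c2)no1)C(F)(F)F`, > 150000 nM

Two compounds of this core carry a number or a limit in a functional assay on A549 cells (Homo sapiens) for inhibition, read by MTT assay, with a stated time of 24 h; on this read-out higher numbers stand for weaker inhibition and lower numbers for stronger inhibition. Among the measured compounds shown here, compound 1 gives 9900 nM in this assay and is the only compound with a measured number. Compound 2 is reported only as a limit of this assay, > 150000 nM, so it sets no number for comparison; the evidence rests on (the limit of > 150000 nM in this assay, at which 1 of the 2 values shown sits). For the measured compounds named here, compound 1 therefore stands alone as the reference point, and no step between measured compounds is available.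

Compound 3, `CCOC(=O)C1=Cc2ccccc2OC1(OCc1cn(CC(=O)Nc2ccccc2Br)nn1)C(F)(F)F`, is not yet measured. It differs from compound 1 by 2-bromophenyl in place of cyclohexyl on an amide-type nitrogen. Going by the values given here, no measured pair shows what this exchange does on this core, so the direction cannot be read from the data. The step from compound 1 to compound 3 is expected to be small, within the usual scatter, and is estimated as a 1.2-fold lower number from compound 1 to compound 3 (0.09 log units; within the scatter). Compound 3 is expected to give about 8000 nM in this assay, with a range from 2000 nM to 40000 nM.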

Compound 3, half-maximal inhibitory concentration: > 150000 nM
Compound 3 ended at the assay's limit; the forecaster's own chance of this, stated with the estimate: 15%; middle value at least 18-fold (1.27 log units) from the limit.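

In this assay, among the compounds shown here, the substituent on the amide-type nitrogen proves to be a sensitive point on the shared core: 2-bromophenyl in place of cyclohexyl gives an at least 15-fold higher number from compound 1 to compound 3 (1.18 log units; beyond the scatter), the first step that can be read. Compound 3 gives > 150000 nM, which is a limit of the assay and not a number, so the step fixes a direction and a minimum size but not a true size. Compound 1 remains the only compound here with a measured number, so the read-out offers no graded comparison around this position: the limit of > 150000 nM in this assay, at which 2 of the 3 values shown sit.

The exchange changes the ring from non-aromatic to aromatic and adds a bromine at once, and the compounds shown do not separate the two; an unsubstituted phenyl on the same nitrogen would do so. Also open, as far as these compounds go, is how narrowly the value of compound 1 depends on cyclohexyl itself, which a cyclopentyl group, a benzyl group or an open hexyl chain at this nitrogen would help to settle.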